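The source may hold more compounds than are shown below. What is called first, only, known or untested is meant among the compounds shown, and "the series" means these compounds.

Measured compounds:
- compound 1, `CC(C)(C)c1ccc(Cn2cc(C#N)c3c(N)ncnc32)cc1`: 3000 nM
- compound 2, `CC(C)(C)c1ccc(Cn2cc(C(=N)S)c3c(N)ncnc32)cc1`: 7000 nM
- compound 3, `Cc1ccccc1Cn1cc(C(=N)S)c2c(N)ncnc21`: > 17000 nM (a limit of the assay, not a number)

In a functional assay on KB cells (Homo sapiens) for cytotoxicity (on this read-out higher numbers stand for weaker inhibition and lower numbers for stronger inhibition), compound 2 gives the highest of the two numbers shown, with compound 1 the nearest at a step of a 2.3-fold higher number from compound 1 to compound 2 (0.37 log units; beyond the scatter). That step swaps the group on the core, not the benzyl ring. For compound 3 only a limit is known, (the limit of > 17000 nM in this assay, at which 1 of the 3 values shown sits), so its distance from the others cannot be put into a number.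

Among the measured compounds shown here, compound 4, `COc1ccc(Cn2cc(C(=N)S)c3c(N)ncnc32)cc1`, has not yet been measured. methoxy in place of tert-butyl on an aromatic carbon No measured step bears on this change: the only one with a number, a 2.3-fold higher number from compound 1 to compound 2 (0.37 log units; beyond the scatter), concerns another position, and compound 3, which differs on the benzyl ring, sits at a limit. The expectation therefore stays close to compound 2, with a wide range and a real chance that only a limit is reported. Compound 4 is expected to give about 10000 nM, between 3000 nM and 30000 nM. The expected step is a 1.4-fold higher number from compound 2 to compound 4 (0.15 log units; within the scatter).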

Compound 4, half-maximal inhibitory concentration: 28000 nM
Estimate against measurement, compound 4: 2.8-fold (0.45 log units) below; low and high end bracket the measured number.
By their numbers in this assay, from the lowest: compound 1; then compound 2; then compound 4.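

In this assay, replacing tert-butyl with methoxy on the benzyl ring gives a 4.0-fold higher number from compound 2 to compound 4 (0.60 log units; beyond the scatter). Among the compounds shown here, this is the first numbered step at this position, and it shows that the number depends on the group on this ring, not just on the group on the core. The change swaps tert-butyl for a smaller group that carries a hydrogen-bond acceptor, but this single pair cannot separate those two differences, and nothing measured here explains the step.

For the compounds shown here, with only two groups at this position having numbers, no trend can be drawn, so an amine, a carboxylic acid or a longer chain there could fall on either side of these values. On these data alone, it also remains open whether methoxy would have the same effect alongside the nitrile of compound 1.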